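The compounds below may be only part of what the source reports. "The series", "measured", "known", "first", "only" and "open" are said of these compounds alone.

In an assay on CHO cells for antagonist activity at transient receptor potential cation channel subfamily V member 1 (Homo sapiens), read by FLIPR (on this read-out higher numbers stand for weaker inhibition and lower numbers for stronger inhibition), compound 3 `CC(C(=O)NCc1ccc(C(F)(F)F)cc1OCc1ccc(F)cc1)c1ccc(NS(C)(=O)=O)c(F)c1` gives 0.5 nM, the lowest of the three numbers recorded. Compound 2 `CC(C)COc1cc(C(F)(F)F)ccc1CNC(=O)C(C)c1ccc(NS(C)(=O)=O)c(F)c1` gives 0.8 nM, and the step of a 1.6-fold lower number from compound 2 to compound 3 (0.20 log units; within the scatter). Compound 1 `CC(C(=O)NCc1ccc(C(F)(F)F)cc1N1CCC(C)(C)CC1)c1ccc(NS(C)(=O)=O)c(F)c1` gives 1.3 nM, and the step of a 2.6-fold lower number from compound 1 to compound 3 (0.41 log units; beyond the scatter). Compound 4 `CC(C(=O)NCc1ccc(C(F)(F)F)cc1SCc1ccco1)c1ccc(NS(C)(=O)=O)c(F)c1` alters the same position once more: ((furan-2-yl)methyl)sulfanyl in place of (4-fluorobenzyl)oxy on an aromatic carbon. For the measured compounds named here, no measured step swaps the oxygen link for a sulfur link, or the six-membered aromatic ring of carbon only for a five-membered aromatic ring with 1 hetero atom; the nearest guide is the change on that chain carbon, which stayed within the scatter. For compound 4 a step of about a 2.0-fold higher number from compound 3 to compound 4 (0.30 log units; within the scatter) is therefore expected, without clear direction. Compound 4 is estimated at 1 nM, between 0.4 nM and 2.5 nM.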

Compound 4, inhibition constant: 3.2 nM
Beside the measured number, compound 4's estimate is 3.2-fold (0.51 log units) below it, outside the stated range (above it).
By their numbers in this assay, from the lowest: compounds 3, 2 and 1 (each within the scatter of the next, the first and the last beyond it); then compound 4.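

Compound 4 stands above all three earlier compounds in this assay, with a 6.4-fold higher number from compound 3 to compound 4 (0.81 log units; beyond the scatter), a 4.0-fold higher number from compound 2 to compound 4 (0.60 log units; beyond the scatter) and a 2.5-fold higher number from compound 1 to compound 4 (0.39 log units; beyond the scatter). For the compounds shown here, the first of these steps is larger than any step among the earlier compounds, so this position responds more strongly to the group it carries than those compounds showed. Nothing available explains the rise.

As far as these compounds go, the change replaces the oxygen link and the six-membered ring together, so their shares remain unknown. A (4-fluorobenzyl)sulfanyl group or a ((furan-2-yl)methyl)oxy group would separate them.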